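Permeability after enlarging the amide group of compound 2

The source may hold more compounds than are shown below. What is called first, only, known or untested is meant among the compounds shown, and "the series" means these compounds.

- Compound 1 `O=C(NCc1cccc(Cl)c1)c1ccc2cn(CCN3CCOC3=O)nc2c1`: 62 nm/s
- Compound 2 `COc1cc(C(=O)N2CCC(O)CC2)cc2nc(NCc3cccc(Cl)c3)oc12`: 71 nm/s
- Compound 3 `COc1cc(C(=O)N2CCC(O)C(C)C2)cc2nc(NCc3cncc(Cl)c3)oc12`: 9.3 nm/s

These three numbers come from an ADME assay on Caco-2 cells (Homo sapiens) for permeability, read by LC-MS, in the apical to basolateral direction, with a stated time of 2 h; a lower number here means that the compound crosses the layer more slowly, a higher number that the compound crosses the layer faster. Compound 2, at 71 nm/s, stands level with compound 1, at 62 nm/s, since the two values lie within the usual scatter of each other. Both sit well clear of compound 3, at 9.3 nm/s.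

The next compound to be measured is compound 4 `COc1cc(C(=O)N2CC(C)C(O)CC2C2CC2)cc2nc(NCc3cccc(Cl)c3)oc12`. It keeps the rest of compound 2 and puts 2-cyclopropyl-4-hydroxy-5-methylpiperidin-1-yl in place of 4-hydroxypiperidin-1-yl on a carbonyl carbon. The hydroxyl-bearing six-membered ring therefore stays, and it gains a cyclopropyl and a methyl group.

Within the data shown here, no two measured compounds differ in only one place, so the data offer no direct guide to the effect of this change. The forecast starts from compound 2 at 71 nm/s and remains wide, since the three measured values already spread considerably. No change beyond the scatter is expected, in either direction: the expected result is a 1.2-fold lower number from compound 2 to compound 4 (0.07 log units; within the scatter). The estimated value for compound 4 is 60 nm/s, with an expected range from 20 nm/s to 160 nm/s.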

Compound 4, apparent permeability: 138 nm/s
Estimate against measurement, compound 4: 2.3-fold (0.36 log units) below; the measured number falls inside the stated range.
By their numbers in this assay, from the lowest: compound 3; then compounds 1, 2 and 4 (each within the scatter of the next, the first and the last beyond it).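

In this assay, putting 2-cyclopropyl-4-hydroxy-5-methylpiperidin-1-yl in place of 4-hydroxypiperidin-1-yl on a carbonyl carbon gives a 1.9-fold higher number from compound 2 to compound 4 (0.29 log units; within the scatter). Among these compounds, this is the first direct comparison at this position. Among the compounds shown here, no earlier pair of compounds differed in only one place. It shows that the group on the carbonyl carbon can grow from 7 to 11 heavy atoms, gaining a cyclopropyl and a methyl group while keeping its hydroxyl-bearing six-membered ring, without a step beyond the usual scatter, and no measurement shown here gives a reason for this result.

Since the cyclopropyl and the methyl group enter together, the compounds shown cannot separate what each one contributes, so a piperidine ring carrying only one of them would be needed to tell them apart. Also open, on these data alone, is whether this position would give a similar number if a group of another kind stood on the ring, such as an amine or a carboxylic acid in place of the hydroxyl group.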